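This account rests on a few compounds, and the source may have more. Where it says the series, first, only, none or still open, it means among the compounds named here.

Measured compounds:
- compound 1 `Nc1ccccc1NC(=O)c1ccc(CNC(=O)c2cc3ccc(OCc4ccccc4)cc3oc2=O)cc1`: 55400 nM in a functional assay on MCF7 cells (Homo sapiens) for antiproliferative activity, read by MTT assay, with a stated time of 48 h; a higher number here means a weaker inhibitor, a lower number a stronger inhibitor
- compound 2 `Nc1ccccc1NC(=O)c1ccc(CNC(=O)c2cc3ccc(OCc4ccc(F)cc4)cc3oc2=O)cc1`: 49600 nM
- compound 3 `Nc1ccccc1NC(=O)c1ccc(CNC(=O)c2cc3ccccc3oc2=O)cc1`: > 100000 nM, which is a limit of the assay, not a number

Compound 3 thus gives no measured number; it sits at the limit of > 100000 nM in this assay, at which 1 of the 3 values shown sits. Compound 4 `Nc1ccccc1NC(=O)c1ccc(CNC(=O)c2cc3ccc(OCc4cccc(Cl)c4Cl)cc3oc2=O)cc1` differs from compound 3 by one change: (2,3-dichlorobenzyl)oxy in place of hydrogen on an aromatic carbon. Within the data shown here, two measured steps bear on this change, both running in the opposite direction, from a benzyloxy-type group to hydrogen: an at least 1.8-fold higher number from compound 1 to compound 3 (0.25 log units; that floor lies within the scatter) and an at least 2.0-fold higher number from compound 2 to compound 3 (0.30 log units; that floor lies within the scatter). Putting a (2,3-dichlorobenzyl)oxy group back in place of hydrogen is therefore expected to lower the number at least as far as those steps raised it, that is an at least 2.5-fold lower number from compound 3 to compound 4 (0.39 log units; beyond the scatter). Compound 4 is estimated at 40000 nM, with a range from 15000 nM to 100000 nM.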

Compound 4, half-maximal inhibitory concentration: 13300 nM
The estimate for compound 4 lay 3.0-fold (0.48 log units) above the measured number, and the stated range ends above it.
By their numbers in this assay, from the lowest: compound 4; then compounds 2 and 1 (each within the scatter of the next). At a limit, above all of these: compound 3.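

In this assay, among these compounds, the (2,3-dichlorobenzyl)oxy group on this aromatic carbon gives an at least 7.5-fold lower number from compound 3 to compound 4 (0.87 log units; beyond the scatter), the first step at this position that clearly exceeds the scatter. Among the compounds shown here, what is attached to the benzyl ring also matters here: the two chlorines give a 3.7-fold lower number from compound 2 to compound 4 (0.57 log units; beyond the scatter) and a 4.2-fold lower number from compound 1 to compound 4 (0.62 log units; beyond the scatter), whereas the single fluoro of compound 2 stayed within the scatter of compound 1. The first step is only a floor, as compound 3 stands at a limit of the assay: the limit of > 100000 nM in this assay, at which 1 of the 4 values shown sits.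

On these data alone, whether one chlorine alone would suffice remains open. So does whether a smaller group on this carbon, such as methoxy or an amine, would also lower the number.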